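A benzyl substituent tested twice on two related cores

A few compounds are considered here, and "the series" means these few. Any claim that something is new, unique, unknown or untested is made for them only; others in the source may bear on it.

Compound 1 `COc1ccc(Cn2cc3cc(C(=N)Nc4ccc(N5CCN(C)CC5)cc4)ncc3n2)cc1` and compound 2 `CN1CCN(c2ccc(NC(=N)c3cc4cn(C)nc4cn3)cc2)CC1` share a core and differ in one place. In a functional assay on HT-1080 cells (Homo sapiens) for cytotoxicity, read by MTT assay, with a stated time of 72 h (a lower number here means a stronger inhibitor, a higher number a weaker inhibitor), compound 2 gives 21000 nM, while compound 1 gives 3200 nM. The change that separates them is 4-methoxyphenyl in place of hydrogen on a saturated chain carbon bound to an aromatic nitrogen and it made a step of a 6.6-fold lower number from compound 2 to compound 1 (0.82 log units; beyond the scatter).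

Compound 3 `Cn1nc(-c2ccccc2)c2cc(C(=N)Nc3cccc(C(F)(F)F)c3)ncc21` is built on a different core, and the difference between the two cores is not broken down here. In this assay compound 3 gives 17800 nM, a number that sits close to that of compound 2 and well above that of compound 1.

Compound 4 `COc1ccc(Cn2nc(-c3ccccc3)c3cc(C(=N)Nc4cccc(C(F)(F)F)c4)ncc32)cc1` has not yet been measured. It stands to compound 3 as compound 1 stands to compound 2: the difference is 4-methoxyphenyl in place of hydrogen on a saturated chain carbon bound to an aromatic nitrogen, and the place is described in the same words for both pairs, so this is the same change made on another core. For the measured compounds named here, the only guide to its effect is the single earlier step, which was measured on one core and now has to be carried across to a second. The step from compound 3 to compound 4 is therefore expected to be about a 5.1-fold lower number from compound 3 to compound 4 (0.71 log units; beyond the scatter), resting on the size of a 6.6-fold lower number from compound 2 to compound 1 (0.82 log units; beyond the scatter). For compound 4 the expected value in this assay is 3500 nM, somewhere between 1000 nM and 12000 nM, with the width reflecting that one earlier example cannot show whether the change behaves alike on a different core.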

Compound 4, half-maximal inhibitory concentration: 46700 nM
Compound 4: middle estimate off by 13-fold (1.13 log units), on the low side, and the stated range ends below it.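

On the core of compound 3, placing 4-methoxyphenyl in place of hydrogen on a saturated chain carbon bound to an aromatic nitrogen gave a 2.6-fold higher number from compound 3 to compound 4 (0.42 log units; beyond the scatter) in this assay, so the larger group here goes with a weaker inhibitor, whereas the same change went with a stronger inhibitor on the core of compound 2. For the compounds shown here, the two steps point in opposite directions, which shows that the effect of this change cannot simply be carried from one core to the other: the same change on two cores in this assay, a 6.6-fold lower number (0.82 log units; beyond the scatter) from compound 2 to compound 1 and a 2.6-fold higher number (0.42 log units; beyond the scatter) from compound 3 to compound 4, 17-fold (1.24 log units) apart, beyond the scatter of two such steps This does not show why the direction reverses, since compound 2 and compound 3 differ in more than one place and only two pairs are available, so the part of the structure that decides the outcome cannot be identified.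

The compounds shown leave open whether a plain benzyl group without the methoxy, or a short chain such as ethyl, would split in the same way on these two cores. They also leave open which single feature sets the direction of the change, the phenyl group of compound 3 or its trifluoromethyl-bearing ring, as neither is varied alone.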